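Amine swap on a shared aminothienopyrimidine core

A few compounds are considered here, and "the series" means these few. Any claim that something is new, unique, unknown or untested is made for them only; others in the source may bear on it.

Compound 1 `Nc1nc(-c2cc3ccccc3o2)nc2sc(CN3CCC(F)CC3)cc12`: 630 nM
Compound 2 `C[C@@H]1CCC[C@H](C)N1Cc1cc2c(N)nc(-c3cccc(C#N)c3)nc2s1`: 460 nM

In an assay on CHO-K1 cells for antagonist activity at adenosine receptor A1 (Homo sapiens), read by a beta-galactosidase reporter, with stated times of 15 min and 6 h (a lower number here means a stronger inhibitor, a higher number a weaker inhibitor), compound 2 gives 460 nM, the lowest of the two numbers, though compound 1 at 630 nM sits within the usual scatter of it, so no order between the two can be claimed.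

Compound 3 `N#Cc1cccc(-c2nc(N)c3cc(CN4CCC(F)CC4)sc3n2)c1` has not yet been measured in this assay. It differs from compound 2 in one place: 4-fluoropiperidin-1-yl in place of 2,6-dimethylpiperidin-1-yl on a saturated chain carbon bound to an aromatic carbon, the same difference read one bond further out being (2,6-dimethylpiperidin-1-yl)methyl to (4-fluoropiperidin-1-yl)methyl. Among the measured compounds shown here, no measured pair shows this step directly, and the two values in hand lie within scatter of each other, so nothing points to a clear direction. The step from compound 2 to compound 3 is therefore expected to be a 1.2-fold higher number from compound 2 to compound 3 (0.08 log units; within the scatter), not beyond the scatter. Compound 3 is estimated at 550 nM, with a range from 200 nM to 1500 nM.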

Compound 3, inhibition constant: 2950 nM
The estimate for compound 3 lay 5.4-fold (0.73 log units) below the measured number; the whole stated range lies below it.
By their numbers in this assay, from the lowest: compounds 2 and 1 (each within the scatter of the next); then compound 3.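

Taken alone in this assay, 4-fluoropiperidin-1-yl in place of 2,6-dimethylpiperidin-1-yl on a saturated chain carbon bound to an aromatic carbon gives a 6.4-fold higher number from compound 2 to compound 3 (0.81 log units; beyond the scatter) and so lies beyond the scatter, which compounds 1 and 2, differing in two places, could not show. With 4-fluoropiperidin-1-yl held constant, 3-cyanophenyl in place of 1-benzofuran-2-yl on an aromatic carbon gives a 4.7-fold higher number from compound 1 to compound 3 (0.67 log units; beyond the scatter) and shows that this second place also moves the number. No measured evidence accounts for either step.

The compounds shown do not separate the loss of the two methyl groups from the arrival of the fluorine, a question that plain piperidin-1-yl on the same carbon would address. They also leave open how morpholin-4-yl or an open-chain amine such as diethylamino would fare there.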